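Notes on compound 3 and the aryl change on the carbonyl

The compounds below may be only part of what the source reports. "The series", "measured", "known", "first", "only" and "open" are said of these compounds alone.

Compound 1 `CN(C(=O)NC(=O)c1cccc(C(F)(F)F)c1)c1nc(C(F)(F)F)c(C(=O)N/N=C/c2ccccc2C(F)(F)F)s1` and compound 2 `CN(C(=O)NC(=O)c1c(Cl)cccc1Cl)c1nc(C(F)(F)F)c(C(=O)N/N=C/c2ccccc2C(F)(F)F)s1` share one core and differ only in the aryl group on a carbonyl carbon. In a functional assay on HeLa cells (Homo sapiens) for inhibition, read by MTT assay, with a stated time of 72 h (a lower number here means a stronger inhibitor, a higher number a weaker inhibitor), compound 1 gives 7.37 ug/mL and compound 2 gives 5.23 ug/mL. Among the compounds with values here, the single measured step, a 1.4-fold lower number from compound 1 to compound 2 (0.15 log units; within the scatter), lies within the scatter, so compound 2 holds the lowest of the two numbers without standing apart from compound 1.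

Compound 3 `CN(C(=O)NC(=O)c1cccc([N+](=O)[O-])c1)c1nc(C(F)(F)F)c(C(=O)N/N=C/c2ccccc2C(F)(F)F)s1` changes the same carbonyl-bound aryl once more: 3-nitrophenyl in place of 2,6-dichlorophenyl on a carbonyl carbon. Within the data shown here, the only measured step that bears on this change is a 1.4-fold lower number from compound 1 to compound 2 (0.15 log units; within the scatter), which also replaced one aryl by another on that carbonyl carbon and moved the number by no more than the scatter. With one such step in hand, no step beyond the scatter is expected in this assay for compound 3 in either direction, and the expected change is a 1.1-fold higher number from compound 2 to compound 3 (0.06 log units; within the scatter). Compound 3 is therefore estimated in this assay at 6 ug/mL, with an expected range from 3 ug/mL to 12 ug/mL; the range is wide on one data point.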

Compound 3, half-maximal inhibitory concentration: 4.15 ug/mL
Estimate against measurement, compound 3: 1.4-fold (0.16 log units) above; measured number inside the range.
By their numbers in this assay, from the lowest: compounds 3, 2 and 1 (each within the scatter of the next).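

The replacement of 2,6-dichlorophenyl by 3-nitrophenyl on the carbonyl carbon brings in a nitro group and changes the counted hydrogen-bond acceptors on this aryl group from 0 to 2, yet this assay shows a 1.3-fold lower number from compound 2 to compound 3 (0.10 log units; within the scatter) for this change. Within the data shown here, compound 1 and compound 3 also give the first direct comparison of two groups on the same aryl framework, with nitro in place of trifluoromethyl on an aromatic carbon: a 1.8-fold lower number from compound 1 to compound 3 (0.25 log units; within the scatter) is the step, so all three aryl groups on this carbonyl carbon now lie within the scatter of one another in this assay and no order can be drawn among them. Nothing on hand gives a measured property of these groups or accounts for these numbers.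

Still open, on these data alone, is whether an amine or a carboxylic acid on this aromatic ring, or a longer alkyl chain in place of the ring, would move the number beyond the scatter in this assay. All three compounds keep the rest of the shared core unchanged, so they say nothing on whether changes elsewhere on that core would give steps of a similar size.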